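The source may hold more compounds than are shown below. What is called first, only, known or untested is meant among the compounds shown, and "the series" means these compounds.

Going by the values given here, in a physicochemical assay for solubility, measured as kinetic solubility, with a stated time of 15 h, at pH 7.4 (on this read-out lower numbers stand for lower solubility and higher numbers for higher solubility), compound 2 (`Cc1ccccc1-c1ccc(O[C@H]2O[C@H](CO)[C@@H](O)[C@H](O)[C@@H]2O)c(Cl)c1`) gives 135 ug/mL and stands as the higher of the two numbers so far. Compound 1 (`OC[C@H]1O[C@H](Oc2ccc(-c3ccc(C(F)(F)F)cc3)cc2Cl)[C@@H](O)[C@@H](O)[C@@H]1O`) gives 22 ug/mL on the same read-out, lower than compound 2 by more than the usual scatter. Compound 3 (`CC(=O)c1ccc(-c2ccc(O[C@H]3O[C@H](CO)[C@@H](O)[C@H](O)[C@@H]3O)c(Cl)c2)cc1`) has not been measured yet. It keeps the core of compound 2 and carries 4-acetylphenyl in place of 2-methylphenyl on an aromatic carbon. Among the compounds with values here, no measured step covers this swap, so the expectation can lean only on the two numbers at hand, with compound 1 at 22 ug/mL as the one lower reference point. A moderate fall beyond the scatter is expected, an estimated 2.7-fold lower number from compound 2 to compound 3 (0.43 log units; beyond the scatter) in this assay on this reasoning. For compound 3 the estimate is 50 ug/mL with an expected range from 15 ug/mL to 130 ug/mL on this read-out.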

Compound 3, solubility: 16 ug/mL
Estimate against measurement, compound 3: 3.1-fold (0.49 log units) above, within the range that was stated.
By their numbers in this assay, from the lowest: compounds 3 and 1 (each within the scatter of the next); then compound 2.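

In this assay, 4-acetylphenyl in place of 2-methylphenyl on this aromatic carbon gives an 8.4-fold lower number from compound 2 to compound 3 (0.93 log units; beyond the scatter) and so shows that the aryl group at this position, meta to a chloro group, can shift the read-out well beyond the scatter. Acetyl in place of trifluoromethyl gives a 1.4-fold lower number from compound 1 to compound 3 (0.14 log units; within the scatter) and stays within the scatter, so these two groups on the outer ring cannot be told apart in this read-out. The data at hand give no reason for either step.

On these data alone, the larger step changes both the group and its place on the ring, so the share of each remains open. As far as these compounds go, it is also open whether an amine or a carboxylic acid at the 4-position of the phenyl ring would give a number nearer that of compound 2.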